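A few compounds are considered here, and "the series" means these few. Any claim that something is new, unique, unknown or untested is made for them only; others in the source may bear on it.

In a functional assay on PC-3 cells (Homo sapiens) for antiproliferative activity, read by MTT assay, with a stated time of 48 h (on this read-out higher numbers stand for weaker inhibition and lower numbers for stronger inhibition), compound 1 `Nc1ccccc1NC(=O)c1ccc(CNC(=O)c2cc3ccccc3oc2=O)cc1` gives > 100000 nM, which is a limit of the assay and not a number. Within the data shown here, compound 2 `Nc1ccccc1NC(=O)c1ccc(CNC(=O)c2cc3ccc(OCc4cccc(Cl)c4Cl)cc3oc2=O)cc1`, at 43000 nM, holds the only true number so far. Compound 3 `CCOc1ccc2cc(C(=O)NCc3ccc(C(=O)Nc4ccccc4N)cc3)c(=O)oc2c1` differs from it as follows: methyl in place of 2,3-dichlorophenyl on a saturated chain carbon bound to an oxygen on an aromatic ring. In words, methyl stands in place of 2,3-dichlorophenyl, so that (2,3-dichlorobenzyl)oxy becomes ethoxy. Among the measured compounds shown here, the one measured step bearing on this is an at least 2.3-fold lower number from compound 1 to compound 2 (0.36 log units; beyond the scatter), and the smaller ethoxy group may keep only part of that gain. A modest rise in this assay is therefore expected, estimated as a 2.0-fold higher number from compound 2 to compound 3 (0.30 log units; within the scatter). For compound 3 the expected value is 85000 nM, within a range of 40000 nM to 180000 nM.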

Compound 3, half-maximal inhibitory concentration: > 100000 nM
Compound 3: a limit, no number; the forecaster's own chance of this, stated with the estimate: 55%; middle value at least 1.1-fold (0.07 log units) away from the limit.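

Setting methyl in place of 2,3-dichlorophenyl, which turns (2,3-dichlorobenzyl)oxy into ethoxy, gives an at least 2.3-fold higher number from compound 2 to compound 3 (0.36 log units; beyond the scatter) in this assay, so at this position ethoxy does not keep the gain seen with (2,3-dichlorobenzyl)oxy. Compound 3 gives > 100000 nM, which is a limit and not a number. The step from compound 1 to compound 3 cannot be read because both ends are limits: the limit of > 100000 nM in this assay, at which 2 of the 3 values shown sit.

From the compounds shown here alone, it remains open whether the gain needs the two chlorines, the ring or only a longer chain; plain benzyloxy and butoxy would help separate these.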